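Lengthening the decyl chain of compound 1 to tetradecyl

The compounds below may be only part of what the source reports. "The series", "measured", "known", "first", "only" and "open" are said of these compounds alone.

Measured compounds:
compound 1, `CCCCCCCCCCNC[C@@H]1OC[C@H](N)[C@@H]1O`, 29600 nM
compound 2, `CCCCCCCCCCNC[C@@H]1OC[C@H](N)[C@H]1O`, > 128000 nM

Going by the values given here, in a functional assay on B16-F10 cells (Mus musculus) for antiproliferative activity, read by MTT assay, with a stated time of 72 h (a lower number here means a stronger inhibitor, a higher number a weaker inhibitor), compound 1 gives 29600 nM, the only plain number among the two values shown. For compound 2 the value of > 128000 nM is a limit of this assay, not a number. The step of an at least 4.3-fold higher number from compound 1 to compound 2 (0.63 log units; beyond the scatter) rests on (the fact that compounds 1 and 2 differ only in the configuration as drawn), and its size is bounded by the limit of > 128000 nM in this assay, at which 1 of the 2 values shown sits.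

Compound 3, `CCCCCCCCCCCCCCNC[C@@H]1OC[C@H](N)[C@@H]1O`, differs from compound 1 by butyl in place of hydrogen on a saturated chain carbon, ten or more bonds along the chain from an amine nitrogen. Among the compounds with values here, the one measured step concerns configuration at the core, not the chain, so it does not bear on this change, and no measured step points in either direction. The author therefore expects a step of a 2.0-fold lower number from compound 1 to compound 3 (0.30 log units; within the scatter), within the scatter or slightly toward a lower number, and estimates compound 3 in this assay at 15000 nM, between 4000 nM and 60000 nM.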

Compound 3, half-maximal inhibitory concentration: 14300 nM
Estimate against measurement, compound 3: 1.0-fold (0.02 log units) above; the range from low to high includes it.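

In this assay, going by these compounds alone, the earlier pair spoke only to configuration at the core, and this is the first reading of a change in the chain: butyl in place of hydrogen on a saturated chain carbon, ten or more bonds along the chain from an amine nitrogen, gives a 2.1-fold lower number from compound 1 to compound 3 (0.32 log units; beyond the scatter). The step is modest, yet it lies beyond the scatter, so the number still moves with a change this far along the chain from the amine nitrogen. Nothing given here accounts for this step.

From the compounds shown here alone, whether a hexadecyl chain, or a chain ending in a carboxylic acid, would take the number further down remains open. So does the effect of the tetradecyl chain on the configuration of compound 2, whose value of > 128000 nM is a limit and not a number.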